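Benzyl substituent swap on the shared core

The compounds below may be only part of what the source reports. "The series", "measured", "known", "first", "only" and "open" are said of these compounds alone.

In a functional assay on HepG2 cells (Homo sapiens) for antiproliferative activity, read by MTT assay, with a stated time of 48 h (on this read-out higher numbers stand for weaker inhibition and lower numbers for stronger inhibition), compound 1 `CCCCc1ccc2c(c1)C(=O)C(=O)N2` gives only a limit, > 10000 nM. Compound 2 `O=C1Nc2ccc(-c3ccc(C(F)(F)F)cc3)cc2C1=O` gives 5430 nM in this assay. For the measured compounds named here, compound 3 `COc1ccc(-c2ccc3c(c2)C(=O)C(=O)N3Cc2ccc(Cl)c(Cl)c2)cc1` gives 990 nM, the lowest of the two numbers so far, with compound 2 standing above it beyond the scatter. Compound 4 `COc1ccc(-c2ccc3c(c2)C(=O)C(=O)N3Cc2cc(C)cc(C)c2)cc1` differs from compound 3 by 3,5-dimethylphenyl in place of 3,4-dichlorophenyl on a saturated chain carbon bound to an amide-type nitrogen in a ring. Going by the values given here, no measured pair in the set isolates this change, so its size cannot be read from the data at hand. A small step from compound 3 to compound 4 is expected, a 1.5-fold higher number from compound 3 to compound 4 (0.18 log units; within the scatter), a mild loss that need not exceed the scatter. Compound 4 is therefore estimated at 1500 nM, with a range from 500 nM to 4500 nM.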

Compound 4, half-maximal inhibitory concentration: 410 nM
The estimate for compound 4 lay 3.7-fold (0.56 log units) above the measured number, outside the stated range (below it).
By their numbers in this assay, from the lowest: compound 4; then compound 3; then compound 2. At a limit, above all of these: compound 1.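

For the compounds shown here, the step of a 2.4-fold lower number from compound 3 to compound 4 (0.38 log units; beyond the scatter) is the first single-place comparison, and it shows that the group on a saturated chain carbon bound to an amide-type nitrogen in a ring affects the read-out. Chlorine is not required there: the all-carbon 3,5-dimethylphenyl gives the lower number, with compound 4 at 410 nM. No measurement shown here bears on the reason for this step.

This one pair changes the kind of substituent and its placement together, leaving the two effects unseparated. 3,5-Dichlorophenyl and 3,4-dimethylphenyl would tell them apart, while an unsubstituted phenyl would set a baseline.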